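A few compounds are considered here, and "the series" means these few. Any claim that something is new, unique, unknown or untested is made for them only; others in the source may bear on it.

Measured compounds in this series:

Compound 1, `CC(=O)c1cccc(NC2=NCCC3(CCCCC3)S2)c1`: 74.7 10^-6 cm/s
Compound 2, `Fc1ccc(NC2=NCCC3(CCCCC3)S2)cc1Cl`: 7.36 10^-6 cm/s
Compound 3, `CCc1cccc(CC)c1NC1=NCCC2(CCCCC2)S1`: 21.6 10^-6 cm/s

All three share one core and differ only in the substituents on the aromatic ring attached to the amine. In a physicochemical assay for permeability (on this read-out lower numbers stand for lower permeability and higher numbers for higher permeability), compound 2 stands lowest of the three numbers. Compound 3 gives the nearest value, higher by a gap beyond the scatter, and compound 1 gives the furthest value, higher by a gap that is also beyond the scatter. Neither of these two differences corresponds to a single-point change, so they say nothing directly about the effect of swapping one halogen for another.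

Compound 4, `Clc1ccc(NC2=NCCC3(CCCCC3)S2)cc1Cl`, has not yet been measured in this assay. It differs from compound 2 in one place: chloro in place of fluoro on an aromatic carbon.

Within the data shown here, no pair of measured compounds shows this change, so the size of the step cannot be read from the data. The expectation is that the step of a 1.5-fold higher number from compound 2 to compound 4 (0.17 log units; within the scatter) is small, upward if anything, and probably within the usual scatter of this assay.

Compound 4 is therefore estimated at 11 10^-6 cm/s, with a range from 4.5 10^-6 cm/s to 27 10^-6 cm/s.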

Compound 4, apparent permeability: 3.1 10^-6 cm/s
The estimate for compound 4 lay 3.5-fold (0.55 log units) above the measured number; measured number below the stated range.
By their numbers in this assay, from the lowest: compound 4; then compound 2; then compound 3; then compound 1.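

In this assay, among these compounds, chloro in place of fluoro on an aromatic carbon, ortho to a chloro group and para to a large group, gives the first single-place step: a 2.4-fold lower number from compound 2 to compound 4 (0.38 log units; beyond the scatter), modest in size but beyond the scatter. The read-out at this position therefore depends on which halogen is present, even though the exchange leaves the counts of hydrogen-bond donors, hydrogen-bond acceptors and net charge unchanged, and the direction of the step is downward. Nothing measured here accounts for the step, so it stands as an observation without an explanation.

On these data alone, only these two halogens are compared at this position, so it remains open how the read-out would respond to hydrogen, bromo, methoxy, nitrile or an amine there, and whether the order seen for fluoro and chloro would extend to any of them. The steps from compound 1 and compound 3 to the halogenated compounds cannot be read because they differ in more than one place, which leaves open whether the same exchange would give a similar step without the neighbouring ortho chloro group.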